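Swapping phenyl for propyl on the ring nitrogen of compound 3

The source may report more compounds than this note shows. Statements on the series, on what has been measured and on what is new or still open speak of the compounds shown alone.

Measured compounds:
compound 1 `CCOCCn1c(N2CCN(CC)CC2)nc2ccccc21`, 18 nM
compound 2 `CCCCCN1CCN(c2nc3ccccc3n2CCOCC)CC1`, 30 nM
compound 3 `CN1CCN(c2nc3ccccc3n2-c2ccccc2)CC1`, 760 nM

In a functional assay on ileum for inhibition of histamine H1 receptor (Cavia porcellus) (on this read-out lower numbers stand for stronger inhibition and higher numbers for weaker inhibition), compound 3 gives the highest number of the three, well beyond the scatter from compound 2 and compound 1. Compound 4 `CCCn1c(N2CCN(C)CC2)nc2ccccc21` differs from it in one place: propyl in place of phenyl on an aromatic nitrogen. Within the data shown here, the only measured step, a 1.7-fold higher number from compound 1 to compound 2 (0.22 log units; within the scatter), concerns a different place and lies within the scatter, so it does not bear on this change. Compound 1 and compound 2 carry a chain on that aromatic nitrogen and give far lower numbers than compound 3, but they also differ at the piperazine, so this is only a hint. A lower number is therefore expected, with caution. Compound 4 is estimated at 120 nM, between 30 nM and 500 nM, an expected step of a 6.3-fold lower number from compound 3 to compound 4 (0.80 log units; beyond the scatter).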

Compound 4, half-maximal inhibitory concentration: 380 nM
Compound 4: the middle estimate sits 3.2-fold (0.50 log units) below what was measured; low and high end bracket the measured number.
By their numbers in this assay, from the lowest: compounds 1 and 2 (each within the scatter of the next); then compounds 4 and 3 (each within the scatter of the next).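

In this assay, putting propyl in place of phenyl on the aromatic nitrogen gives a 2.0-fold lower number from compound 3 to compound 4 (0.30 log units; within the scatter). With the 4-methylpiperazin-1-yl group in place, this position therefore accepts either an aromatic ring or a short open chain with no clear change in the number, so a phenyl ring is not needed here. Among these compounds, nothing measured so far explains this result. Going by these compounds, whether a benzyl group or a longer chain on this nitrogen would shift the number remains open. So does the effect of an amine at the end of such a chain.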